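Methoxy to Nitro: Does Vero Cell Toxicity Change?

A few compounds are considered here, and "the series" means these few. Any claim that something is new, unique, unknown or untested is made for them only; others in the source may bear on it.

Three compounds share a common core and differ only in one group on an aromatic ring. Compound 1 `COc1ccc(C2SCC(=O)N2CCN2CCCCC2)cc1` carries a methoxy group, compound 2 `O=C1CSC(c2ccc([N+](=O)[O-])cc2)N1CCN1CCCCC1` a nitro group, and compound 3 `COc1ccccc1C1SCC(=O)N1CCN1CCCCC1` again a methoxy group at another position; compound 3 has the same atoms as compound 1, joined differently, and the difference between the two cores is not broken down here. In an ADME assay on Vero cells (Chlorocebus sabaeus) for cytotoxicity, read by neutral red uptake, tested at 12.3 ug/mL (a lower number here means a stronger effect, a higher number a weaker effect of the compound at the concentration tested), compound 1 gives 100%, compound 2 gives 100%, and compound 3 gives 100%. The change from compound 1 to compound 2, (nitro in place of methoxy on an aromatic carbon), produced no change at the digits printed from compound 1 to compound 2 (within the scatter).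

Compound 4 `O=C1CSC(c2ccccc2[N+](=O)[O-])N1CCN1CCCCC1` arises from compound 3 by nitro in place of methoxy on an aromatic carbon. This is the same kind of change as before, not the same: around the place, the nitro of compound 2 sits para to a large group, whereas in compound 4 it sits ortho to a large group. Compound 4 is expected to show no change at the digits printed from compound 3 to compound 4 (within the scatter), because the same kind of change gave no change at the digits printed from compound 1 to compound 2 (within the scatter). Compound 4 is therefore estimated at 100%, between 88% and 100%.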

Compound 4, a percentage reported as activity, at one concentration (the size of the read-out at that concentration, not a potency): 100%
Beside the measured number, compound 4's estimate shows no gap at the digits printed, within the range that was stated.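

In this assay, nitro in place of methoxy on an aromatic carbon produced no change at the digits printed from compound 3 to compound 4 (within the scatter), and this step can be set beside the same change on the other core: the same change on two cores in this assay, no change at the digits printed (within the scatter) from compound 1 to compound 2 and no change at the digits printed (within the scatter) from compound 3 to compound 4, 0 percentage points apart, within the scatter of two such steps. Within these two pairs, then, the change carries from one core to the other with the same outcome, even though the nitro of compound 4 sits ortho to a large group. This does not show that the change is harmless to cells in general, since all four compounds print the same value and the comparison rests on a single tested concentration in one cell type, so a difference between the cores could appear only under other conditions.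

The compounds shown leave open whether an amine, a carboxylic acid or a longer chain at the same place on the aromatic ring would read the same in this assay. They also leave open whether the two cores would still agree at a higher concentration.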